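Halogen swaps on a kynurenine monooxygenase scaffold

The source may hold more compounds than are shown below. What is called first, only, known or untested is meant among the compounds shown, and "the series" means these compounds.

The study measures three compounds in an assay for inhibition of kynurenine 3-monooxygenase (Rattus norvegicus), tested at 10 uM (a higher number here means more inhibition at the concentration tested (going by the name of the read-out), a lower number less inhibition), and asks what a fourth will give. Compound 2 `COC(=O)C(=N)/C=C(\O)c1ccccc1` gives 3% in this assay, the lowest of the three numbers; its nearest neighbour is compound 1 `COC(=O)C(=O)/C=C(\O)c1cccc(Cl)c1Cl`, which in this assay gives 14%, and the furthest is compound 3 `COC(=O)C(=N)/C=C(\O)c1ccccc1Cl`, which in this assay gives 31%. Among the compounds with values here, compound 1 carries a different carbonyl group as well as two chloro groups, so no single step links it to compound 2, and only their two values can be set side by side.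

The unmeasured compound 4 `COC(=O)C(=N)/C=C(\O)c1cccc(Br)c1` differs from compound 2 by bromo in place of hydrogen on an aromatic carbon. Within the data shown here, the one measured step that bears on it is a number 28 percentage points higher from compound 2 to compound 3 (beyond the scatter), a chloro entering at another position of the same ring. A bromo at a different place need not repeat that gain, so a smaller upward step is expected, one that may not rise beyond the scatter.

Compound 4 is therefore expected to give about 15% in this assay, within a range of 2% to 32%, which would mean an estimated a number 12 percentage points higher from compound 2 to compound 4 (beyond the scatter).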

Compound 4, a percentage reported as inhibition, at one concentration (the size of the read-out at that concentration, not a potency): 0%
For compound 4 the middle estimate is 15 percentage points above the measured one, and the stated range ends above it.
By their numbers in this assay, from the lowest: compounds 4 and 2 (each within the scatter of the next); then compound 1; then compound 3.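

In this assay, within the data shown here, the result gives the first reading of a substituent at this place on the ring, an aromatic carbon meta to a group of 9 heavy atoms: bromo in place of hydrogen brings a number 3 percentage points lower from compound 2 to compound 4 (within the scatter) and so shows no measurable gain over the unsubstituted ring of compound 2. The earlier rise of a number 28 percentage points higher from compound 2 to compound 3 (beyond the scatter) therefore does not hold for every halogen at every place on this ring, although compound 3 and compound 4 differ in both the halogen and its place, so these two steps cannot show which of the two matters. Nothing among the data shown accounts for this outcome.

The compounds shown leave open whether chloro at the place bromo holds in compound 4, or bromo at the place chloro holds in compound 3, would separate the effect of the halogen from that of its place. They also leave open what an amine, a carboxylic acid or a methoxy group would give at this same aromatic carbon.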